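Aryl sulfonate ureas: a cyclopentyl substituent on the urea

The compounds below may be only part of what the source reports. "The series", "measured", "known", "first", "only" and "open" are said of these compounds alone.

Measured so far in a functional assay on MCF7 cells (Homo sapiens) for antiproliferative activity, read by sulforhodamine B assay, with a stated time of 48 h; a lower number here means a stronger inhibitor, a higher number a weaker inhibitor:
compound 1 `CCC(=O)Nc1ccc(S(=O)(=O)Oc2ccccc2C(C)C)cc1` gives 11000 nM;
compound 2 `CCNC(=O)Nc1ccc(S(=O)(=O)Oc2ccccc2C(C)C)cc1` gives 10000 nM;
compound 3 `CC(C)c1ccccc1OS(=O)(=O)c1ccc(NC(=O)NCCCCl)cc1` gives 7400 nM.

Compound 3 holds the lowest of these numbers, but the step of a 1.5-fold lower number from compound 1 to compound 3 (0.17 log units; within the scatter) and the step of a 1.4-fold lower number from compound 2 to compound 3 (0.13 log units; within the scatter) both fall within the scatter, so none of the three can be set apart from the others. Compound 4 `CC(C)c1ccccc1OS(=O)(=O)c1ccc(NC(=O)NCC2CCCC2)cc1` has not been measured; it differs from compound 3 by cyclopentyl in place of 2-chloroethyl on a saturated chain carbon bound to an amide-type nitrogen. Among the compounds with values here, the only steps that bear on it, the change of the urea substituent from compound 1 to compound 3 and the lengthening from compound 2 to compound 3, were small. Compound 4 is therefore expected to show a step of a 1.1-fold lower number from compound 3 to compound 4 (0.02 log units; within the scatter) in this assay, no larger than the scatter. Compound 4 is estimated at 7000 nM, within 3000 nM to 18000 nM.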

Compound 4, half-maximal inhibitory concentration: 7100 nM
For compound 4 the middle estimate is 1.0-fold (0.01 log units) below the measured one; the measured number falls inside the stated range.
By their numbers in this assay, from the lowest: compounds 4, 3, 2 and 1 (each within the scatter of the next).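

At this saturated chain carbon bound to an amide-type nitrogen, the result shows that a five-membered ring of carbon only can stand in place of the chlorine-bearing 2-chloroethyl without the number in this assay leaving the scatter (a 1.0-fold lower number from compound 3 to compound 4 (0.02 log units; within the scatter)). Cyclopentyl in place of methyl (a 1.4-fold lower number from compound 2 to compound 4 (0.15 log units; within the scatter)) and (cyclopentylmethyl)amino in place of ethyl on the carbonyl carbon (a 1.5-fold lower number from compound 1 to compound 4 (0.19 log units; within the scatter)) also stay within the scatter, so the four compounds still cannot be set apart. No evidence at hand accounts for this flat picture. Still open, going by these compounds, is whether any group here can move the number beyond the scatter, for example an amine or a carboxylic acid at the end of the chain.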